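Swapping Hydroxy for Fluoro on a Weakly Active Lactone

A few compounds are considered here, and "the series" means these few. Any claim that something is new, unique, unknown or untested is made for them only; others in the source may bear on it.

For the measured compounds named here, compound 2 `O=C1OC(c2cc(O)cc(O)c2)C(c2ccc(O)cc2)=C1O` is the only compound here with a number. In an assay on blood for inhibition of Polyunsaturated fatty acid 5-lipoxygenase (Homo sapiens), tested at 100 uM (on this read-out higher numbers stand for a stronger effect at the one concentration tested and lower numbers for a weaker effect), compound 2 gives 11.6%, a weak effect at the single concentration tested. Compound 1 `O=C1OC(c2ccc(OCc3ccccc3)cc2)C(c2ccc(O)cc2)=C1O`, a close relative, gives "not determined" (no result reported) in this assay, so compound 2 stands alone. Compound 3 `O=C1OC(c2cc(O)cc(O)c2)C(c2ccc(F)cc2)=C1O` differs from compound 2 by fluoro in place of hydroxy on an aromatic carbon. Going by the values given here, no measured pair shows what this change does, so a step no larger than the usual scatter, in either direction, is expected. The expected step is a number 1.6 percentage points lower from compound 2 to compound 3 (within the scatter). Compound 3 is thus estimated at 10%, in the range 0% to 25%.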

Compound 3, a percentage reported as activity, at one concentration (the size of the read-out at that concentration, not a potency): 10.7%
Estimate against measurement, compound 3: 0.7 percentage points below, within the range that was stated.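

In this assay the change from 4-hydroxyphenyl to 4-fluorophenyl gives a number 0.9 percentage points lower from compound 2 to compound 3 (within the scatter) and leaves both compounds weak, so the two cannot be told apart. At this position, then, the hydroxy with its hydrogen-bond donor and acceptor is not needed to keep this small effect at the one concentration tested. Nothing available explains why the swap changes so little.

Open, on these data alone, is whether an amine, a carboxylic acid or a longer chain such as butoxy at this position would lift the read-out clear of the scatter. Also open, as far as these compounds go, is how compound 2 and compound 3 compare in potency, which a single concentration cannot show.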